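Methoxycarbonyl to benzyloxycarbonyl on the shared core

A few compounds are considered here, and "the series" means these few. Any claim that something is new, unique, unknown or untested is made for them only; others in the source may bear on it.

In a functional assay on HepG2 cells (Homo sapiens) for antiproliferative activity, read by MTT assay, with a stated time of 48 h (on this read-out lower numbers stand for stronger inhibition of growth and higher numbers for weaker inhibition of growth), compound 1 (`COc1cccc(C2=NN(C(=O)OCc3ccccc3)C(c3cc(OC)c(OC)c(OC)c3)C2)c1`) reads > 10000 nM as a limit of the assay and not a number. Going by the values given here, compound 2 (`COC(=O)N1N=C(c2ccc(OC)cc2)CC1c1cc(OC)c(OC)c(OC)c1`) gives 1710 nM as the only true number so far, so it has no second number to be ranked against.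

Compound 3 (`COc1ccc(C2=NN(C(=O)OCc3ccccc3)C(c3cc(OC)c(OC)c(OC)c3)C2)cc1`) differs from compound 2 by phenyl in place of hydrogen on a saturated chain carbon bound to an oxygen next to a carbonyl group. The same difference reads as methoxycarbonyl to benzyloxycarbonyl.

Among the compounds with values here, no measured step shows what this change does. Within the data shown here, the one indirect guide is compound 1, which also carries benzyloxycarbonyl and stands at > 10000 nM as a limit. The expectation therefore leans toward higher numbers in this assay and a step beyond the usual scatter, with a real chance that only a limit is reported. The estimated step of a 2.6-fold higher number from compound 2 to compound 3 (0.42 log units; beyond the scatter) is of moderate size and remains uncertain. For compound 3 the estimate is 4500 nM with an expected range from 900 nM to 20000 nM in this wide first guess.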

Compound 3, concentration for 50% growth inhibition: > 10000 nM
Compound 3: a limit, no number; the forecaster's own chance of this, stated with the estimate: 30%; middle value at least 2.2-fold (0.34 log units) from the limit.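

In this assay the change from methoxycarbonyl to benzyloxycarbonyl now has a step of its own, with 4-methoxyphenyl held constant on the shared core: an at least 5.8-fold higher number from compound 2 to compound 3 (0.76 log units; beyond the scatter). Going by these compounds alone, this is the first direct sign that growth inhibition at this position is sensitive to phenyl in place of hydrogen on a saturated chain carbon bound to an oxygen next to a carbonyl group. Compound 1 had no methoxycarbonyl partner and could only hint at the effect of benzyloxycarbonyl. From the compounds shown here alone, only a minimum size can be read for the step, and the true size stays unknown: the limit of > 10000 nM in this assay, at which 2 of the 3 values shown sit.

The step from compound 1 to compound 3 cannot be read, so the choice between 3-methoxyphenyl and 4-methoxyphenyl remains unresolved with benzyloxycarbonyl in place. Also open, going by these compounds, is where along the path from methoxycarbonyl to benzyloxycarbonyl the loss sets in, and whether it belongs to the phenyl ring or to chain length: ethoxycarbonyl or a longer chain without the ring would address that, and a benzyl group carrying an amine or a carboxylic acid would test the ring itself.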